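The compounds below may be only part of what the source reports. "The series", "measured", "known", "first", "only" and "open" are said of these compounds alone.

Compound 1 `CC(=O)/C(=N\Nc1ccccc1Cl)Nc1cccc(Cl)c1` gives 417 nM; 417 nM (2 entries) in an assay on isolated protein for binding affinity to corticotropin-releasing factor receptor 1 (Homo sapiens) (on this read-out lower numbers stand for stronger inhibition and higher numbers for weaker inhibition), and compound 2 `COc1cccc(N/C(=N/Nc2ccccc2Cl)C(C)=O)c1` gives 652 nM in this assay; the two values lie close together, and the number for compound 2 is the only one it has, a further measurement not having yielded a single value. Compound 3 `CCOc1cccc(N/C(=N/Nc2ccccc2Cl)C(C)=O)c1` differs from compound 2 by methyl in place of hydrogen on a saturated chain carbon bound to an oxygen on an aromatic ring. Among the compounds with values here, no comparable step is available among the measured compounds, so the change is expected to stay within the usual scatter, as a 1.2-fold higher number from compound 2 to compound 3 (0.06 log units; within the scatter). Compound 3 is therefore estimated at 750 nM in this assay, with a range from 350 nM to 1600 nM.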

Compound 3, inhibition constant: > 10000 nM
Compound 3: a limit, no number; the forecaster's own chance of this, stated with the estimate: 5%; middle value at least 13-fold (1.12 log units) from the limit.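

Methoxy to ethoxy is a small change, yet in this assay it gives an at least 15-fold higher number from compound 2 to compound 3 (1.18 log units; beyond the scatter), so this position responds sharply to a single added methyl, which compounds 1 and 2 alone could not show. The result for compound 3 is a limit, not a number: the limit of > 10000 nM in this assay, at which 1 of the 3 values shown sits.

The compounds shown leave open how far the true value of compound 3 lies past that limit. They also leave open whether a longer chain, such as propoxy, or an amine at the end of the chain would behave like ethoxy or like methoxy.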